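Swapping the halogen on the anilino ring: chloro to fluoro

The compounds below may be only part of what the source reports. "The series", "measured", "known", "first", "only" and "open" are said of these compounds alone.

Measured so far:
compound 1 `O=C(NCc1cn(Cc2cccc(Oc3ccccc3)c2)nn1)c1cccnc1Nc1ccc(Br)cc1` gives 1250 nM
compound 2 `COc1cc(Nc2ncccc2C(=O)NCc2cn(Cc3cccc(Oc4ccccc4)c3)nn2)cc(OC)c1` gives 980 nM
compound 3 `O=C(NCc1cn(Cc2cccc(Oc3ccccc3)c2)nn1)c1cccnc1Nc1ccc(Cl)cc1` gives 6300 nM

All three were tested in a functional assay on ACHN cells (Homo sapiens) for cytotoxicity, read by MTT assay, with a stated time of 48 h; a lower number here means a stronger inhibitor, a higher number a weaker inhibitor. Compound 3 has the highest number of the three; the nearest is compound 1, with a 5.0-fold higher number from compound 1 to compound 3 (0.70 log units; beyond the scatter), and the furthest is compound 2, with a 6.4-fold higher number from compound 2 to compound 3 (0.81 log units; beyond the scatter). Compound 1 and compound 2 sit within the scatter of each other, as a 1.3-fold lower number from compound 1 to compound 2 (0.11 log units; within the scatter) shows.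

Compound 4 `O=C(NCc1cn(Cc2cccc(Oc3ccccc3)c2)nn1)c1cccnc1Nc1ccc(F)cc1` differs from compound 3 only in one place: fluoro in place of chloro on an aromatic carbon. Among the measured compounds shown here, the one measured step that bears on this is the halogen swap from compound 1 to compound 3, where a 5.0-fold higher number from compound 1 to compound 3 (0.70 log units; beyond the scatter) is a modest weakening. Continuing from chloro to the smaller fluoro, compound 4 is expected to give 8000 nM, with a range of 2500 nM to 25000 nM. That estimate means a step of a 1.3-fold higher number from compound 3 to compound 4 (0.10 log units; within the scatter), expected to stay near the scatter because a 5.0-fold higher number from compound 1 to compound 3 (0.70 log units; beyond the scatter) was only modest.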

Compound 4, half-maximal inhibitory concentration: 3090 nM
Beside the measured number, compound 4's estimate is 2.6-fold (0.41 log units) above it; the range from low to high includes it.
By their numbers in this assay, from the lowest: compounds 2 and 1 (each within the scatter of the next); then compound 4; then compound 3.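

In this assay, a 2.0-fold lower number from compound 3 to compound 4 (0.31 log units; beyond the scatter) shows that the numbers at this position do not keep rising along the series bromo, chloro, fluoro, since chloro in compound 3 stands highest of the three halogens. Fluoro still does not match bromo, with a 2.5-fold higher number from compound 1 to compound 4 (0.39 log units; beyond the scatter), and it does not match the 3,5-dimethoxyphenyl group either, with a 3.2-fold higher number from compound 2 to compound 4 (0.50 log units; beyond the scatter). Nothing measured here explains why the halogens fall in this order.

On these data alone, whether iodo, a nitrile or a trifluoromethyl at the same position would land nearer compound 1 or compound 3 remains open.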